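Notes on the series: compound 2 to compound 4

The source may hold more compounds than are shown below. What is called first, only, known or untested is meant among the compounds shown, and "the series" means these compounds.

Measured so far in an assay for inhibition of Amine oxidase [flavin-containing] A (Rattus norvegicus), with a stated time of 60 min; a higher number here means a weaker inhibitor, a lower number a stronger inhibitor:
- compound 1, `CNC(=S)N1N=C(c2ccc(C)cc2)CC1c1ccc[nH]1`, gives 295000 nM in this assay.
- compound 2, `CCCNC(=S)N1N=C(c2ccc(C)cc2)CC1c1ccc[nH]1`, gives 369000 nM in this assay.
- compound 3, `CCNC(=S)N1N=C(c2ccc(OC)cc2)CC1c1ccc[nH]1`, gives 400000 nM in this assay.

Compound 2 stands second highest of the three numbers; compound 3 is nearest to it and compound 1 furthest, and both gaps are within the scatter. Among the measured compounds shown here, the single step in one place, a 1.3-fold higher number from compound 1 to compound 2 (0.10 log units; within the scatter), concerns the chain on the amide-type nitrogen, not the aromatic substituent.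

Compound 4, `CCCNC(=S)N1N=C(c2ccc(OC)cc2)CC1c1ccc[nH]1`, differs from compound 2 by methoxy in place of methyl on an aromatic carbon. For the measured compounds named here, no measured step changes that group alone. Compound 1 and compound 3 differ both in the chain and in this group, and their values lie within the scatter of each other, so they give no sign of a shift tied to the methoxy group either way. In this assay the expected step is therefore a 1.1-fold higher number from compound 2 to compound 4 (0.04 log units; within the scatter), that is none beyond the scatter. Compound 4 is estimated at 400000 nM in this assay, with a range from 200000 nM to 800000 nM.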

Compound 4, half-maximal inhibitory concentration: 409000 nM
For compound 4 the middle estimate is 1.0-fold (0.01 log units) below the measured one; the measured number falls inside the stated range.
By their numbers in this assay, from the lowest: compounds 1, 2, 3 and 4 (each within the scatter of the next).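

In this assay, the change from 4-methylphenyl to 4-methoxyphenyl can now be read alone: a 1.1-fold higher number from compound 2 to compound 4 (0.04 log units; within the scatter) shows that methoxy in place of methyl on an aromatic carbon, para to a large group, does not take the number outside the scatter. The chain on the amide-type nitrogen can also now be read with the 4-methoxyphenyl group held constant, and a 1.0-fold higher number from compound 3 to compound 4 (0.01 log units; within the scatter) is likewise within the scatter for methyl in place of hydrogen, two bonds along the chain from that nitrogen. Nothing available bears on the reason for either result.

Going by these compounds, it remains open whether a carboxylic acid, an amine or chlorine in place of methoxy at this position would give a step beyond the scatter. The same question stands for a longer chain on the amide-type nitrogen.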